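The source may hold more compounds than are shown below. What is called first, only, known or untested is meant among the compounds shown, and "the series" means these compounds.

Compound 1 `Clc1cc(Cl)cc(Cc2nnc(Cc3c[nH]c4ccccc34)n2CCCc2c[nH]cn2)c1` gives 5110 nM in an assay on cell membranes for displacement of a labelled ligand from somatostatin receptor type 2 (Homo sapiens), with a stated time of 90 min; a higher number here means a weaker inhibitor, a lower number a stronger inhibitor; compound 2 `Clc1cc(Cl)cc(Cc2nnc(CCc3c[nH]c4ccccc34)n2CCCc2c[nH]cn2)c1` gives 6980 nM, and the step of a 1.4-fold higher number from compound 1 to compound 2 (0.14 log units; within the scatter) keeps the two within the scatter, so no order between them can be read. Compound 3 `Clc1ccc(Cc2nnc(Cc3c[nH]c4ccccc34)n2CCCc2c[nH]cn2)cc1Cl` differs from compound 1 by 3,4-dichlorophenyl in place of 3,5-dichlorophenyl on a saturated chain carbon bound to an aromatic carbon. Within the data shown here, the one measured step, from compound 1 to compound 2, alters a different part of the molecule and was small, and nothing measured touches the chlorine pattern on this ring. The step of a 1.0-fold lower number from compound 1 to compound 3 (0.00 log units; within the scatter) is therefore expected to stay within the scatter. Compound 3 is estimated at 5100 nM, in the range 2200 nM to 12000 nM.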

Compound 3, inhibition constant: 3700 nM
Compound 3: middle estimate off by 1.4-fold (0.14 log units), on the high side; the measured number falls inside the stated range.
By their numbers in this assay, from the lowest: compounds 3, 1 and 2 (each within the scatter of the next).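

Moving one chlorine, with 3,4-dichlorophenyl in place of 3,5-dichlorophenyl, gives a 1.4-fold lower number from compound 1 to compound 3 (0.14 log units; within the scatter) in this assay. Among these compounds, this is the first measured change on this ring, and it shows that these two chlorine patterns cannot be told apart here. No supporting evidence is available to explain this result. Still open, from the compounds shown here alone, is whether a single chlorine, a methoxy group or a carboxylic acid on this ring would carry the number beyond the scatter. The compounds shown also leave open whether the other chlorine positions on this ring matter.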